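The source may hold more compounds than are shown below. What is called first, only, known or untested is meant among the compounds shown, and "the series" means these compounds.

Measured in an in vivo ADME assay on the whole organism (plasma, strain Sprague-Dawley) for pharmacokinetics, with Rattus norvegicus as the target; a lower number here means slower removal, a higher number faster removal of the compound:
Compound 1 `Cc1cc([C@@H]2C[C@H]2C(=O)O)ccc1-c1noc(-c2ccc(OC(C)C)c(C(F)(F)F)c2)n1`: 2.4 mL/min/kg
Compound 2 `Cc1cc(C(C)CC(=O)O)ccc1-c1noc(-c2ccc(OC(C)C)c(C(F)(F)F)c2)n1`: 2.9 mL/min/kg
Compound 3 `Cc1nc(CCC(=O)O)ccc1-c1noc(-c2ccc(OC(C)C)c(C#N)c2)n1`: 1.2 mL/min/kg

Compound 2 gives 2.9 mL/min/kg. The gap to its nearest neighbour is a 1.2-fold higher number from compound 1 to compound 2 (0.08 log units; within the scatter), so those two count as level. Compound 3 gives 1.2 mL/min/kg, a lower number than that of compound 2 and a gap beyond the scatter.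

Compound 4 `Cc1cc(CCC(=O)O)ccc1-c1noc(-c2ccc(OC(C)C)c(C(F)(F)F)c2)n1` comes from compound 2 by one small edit: hydrogen in place of methyl on a saturated chain carbon bound to an aromatic carbon and a saturated chain carbon. This puts hydrogen in place of methyl on a saturated chain carbon bound to an aromatic carbon and a saturated chain carbon, turning 1-(carboxymethyl)ethyl into 2-carboxyethyl.

Among the measured compounds shown here, no measured pair isolates this edit. For the measured compounds named here, the closest evidence is the one measured step at the same chain, where 1-(carboxymethyl)ethyl replaces 2-carboxycyclopropyl, and that step stayed within the scatter. Going by the values given here, compound 3 carries the 2-carboxyethyl chain too, but it differs from compound 4 elsewhere, so its value gives no clean step.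

On this evidence, no change beyond the scatter is expected, and the estimated step is a 1.1-fold lower number from compound 2 to compound 4 (0.05 log units; within the scatter). Compound 4 is expected at 2.6 mL/min/kg, with an estimated range from 1.2 mL/min/kg to 6 mL/min/kg.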

Compound 4, clearance: 8.7 mL/min/kg
For compound 4 the middle estimate is 3.3-fold (0.52 log units) below the measured one; the measured number lies above the stated range.
By their numbers in this assay, from the lowest: compounds 3, 1 and 2 (each within the scatter of the next, the first and the last beyond it); then compound 4.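

In this assay, among the compounds shown here, the saturated chain carbon bound to an aromatic carbon and a saturated chain carbon proves sensitive to this change: losing the methyl there gives the first step beyond the scatter at this chain (a 3.0-fold higher number from compound 2 to compound 4 (0.48 log units; beyond the scatter)), and the plain 2-carboxyethyl chain also stands apart from the ring-closed chain (a 3.6-fold higher number from compound 1 to compound 4 (0.56 log units; beyond the scatter)). The earlier step at this chain (a 1.2-fold higher number from compound 1 to compound 2 (0.08 log units; within the scatter)) had shown only that 2-carboxycyclopropyl and 1-(carboxymethyl)ethyl are level, so it is the unbranched chain that separates from both, a pattern that rests on these three compounds alone, since compound 3 also carries 2-carboxyethyl but differs in more than one place and cannot be compared. Nothing in the available data accounts for this rise.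

On these data alone, it remains open whether an ethyl group or a second methyl on the same carbon would keep the number as low as a single methyl does. As far as these compounds go, it is equally open whether adding a methyl to the chain of compound 3, with its nitrile, would produce a step of similar size.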